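Chlorophenyl to fluorophenyl at the shared core

The compounds below may be only part of what the source reports. "The series", "measured", "known", "first", "only" and "open" are said of these compounds alone.

Compound 1 `N#Cc1c(-c2ccccc2Cl)c(C#N)c(=O)n(/N=C/c2cn(-c3ccccc3)nc2-c2ccccc2)c1N`, compound 2 `N#Cc1c(-c2cccc(Cl)c2)c(C#N)c(=O)n(/N=C/c2cn(-c3ccccc3)nc2-c2ccccc2)c1N` and compound 3 `N#Cc1c(-c2ccc(Cl)cc2)c(C#N)c(=O)n(/N=C/c2cn(-c3ccccc3)nc2-c2ccccc2)c1N` differ only in where the chlorine sits on the phenyl ring. In an ADME assay on HeLa cells (Homo sapiens) for cytotoxicity, read by MTT assay (on this read-out higher numbers stand for weaker inhibition and lower numbers for stronger inhibition), compound 1 gives the assay limit > 200 ug/mL. In this assay compound 2 likewise gives the limit > 200 ug/mL. In this assay compound 3 stands at the limit > 200 ug/mL. The steps a step that the two limits leave unreadable from compound 1 to compound 2, a step that the two limits leave unreadable from compound 1 to compound 3 and a step that the two limits leave unreadable from compound 2 to compound 3 cannot be sized, because of the limit of > 200 ug/mL in this assay, at which 3 of the 3 values shown sit. Compound 4 `N#Cc1c(-c2cccc(F)c2)c(C#N)c(=O)n(/N=C/c2cn(-c3ccccc3)nc2-c2ccccc2)c1N` carries 3-fluorophenyl in place of 4-chlorophenyl on an aromatic carbon. Among the compounds with values here, no measured step bears on this change, so no step beyond the scatter is expected in this assay; the estimate a step that the limit leaves unreadable from compound 3 to compound 4 rests on the shared limit. Compound 4 is expected at 250 ug/mL, between 120 ug/mL and 600 ug/mL.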

Compound 4, half-maximal inhibitory concentration: > 200 ug/mL
Compound 4: a limit, no number; the forecaster's own chance of this, stated with the estimate: 80%; the middle value lies beyond the limit too.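

Compound 4 also gives only a limit in this assay, so its steps from compound 1, compound 2 and compound 3 cannot be read, because all four compounds share one limit: the limit of > 200 ug/mL in this assay, at which 4 of the 4 values shown sit.

From the compounds shown here alone, whether any change of chloro or fluoro on the phenyl ring alters the read-out in this assay stays open.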